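The source may hold more compounds than are shown below. What is called first, only, known or untested is meant among the compounds shown, and "the series" means these compounds.

Measured so far:
compound 1 `O=[N+]([O-])C1=Cc2cc(C#Cc3ccc(C(F)(F)F)cc3)ccc2OC1C(F)(F)F` — 5220 nM
compound 2 `CC[Si](C#Cc1cccc2c1C=C([N+](=O)[O-])C(C(F)(F)F)O2)(CC)CC` — 4770 nM
compound 3 `COC(=O)/C=C/c1ccc2c(c1)C=C([N+](=O)[O-])C(C(F)(F)F)O2` — 2570 nM

Of the compounds shown here, three sharing one core have been tested in an assay on 1321N1 cells for antagonist activity at P2Y purinoceptor 6 (Homo sapiens), read by FLIPR and calcium flux; on this read-out higher numbers stand for weaker inhibition and lower numbers for stronger inhibition. Compound 1 `O=[N+]([O-])C1=Cc2cc(C#Cc3ccc(C(F)(F)F)cc3)ccc2OC1C(F)(F)F` gives 5220 nM, the highest of the three numbers. Compound 2 `CC[Si](C#Cc1cccc2c1C=C([N+](=O)[O-])C(C(F)(F)F)O2)(CC)CC` gives 4770 nM in this assay, and this number sits so close to that of compound 1 that the two cannot be told apart within the scatter of repeated measurements. Compound 3 `COC(=O)/C=C/c1ccc2c(c1)C=C([N+](=O)[O-])C(C(F)(F)F)O2` gives 2570 nM in this assay, a number lower than that of compound 1 by a margin beyond the scatter, so compound 3 does inhibit more strongly than compound 1.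

Compound 4 `O=[N+]([O-])C1=Cc2cc(C#Cc3ccc(Cl)cc3)ccc2OC1C(F)(F)F` has not yet been measured. It differs from compound 1 in one place: chloro in place of trifluoromethyl on an aromatic carbon. Within the data shown here, no pair among the measured compounds shows what this kind of exchange does here, so there is no measured step to lean on. Both groups are small and uncharged, and the rest of the molecule is untouched, so the expectation is a step of modest size, not clearly beyond the scatter in either direction: a 1.2-fold lower number from compound 1 to compound 4 (0.06 log units; within the scatter) is the step estimated. In this assay compound 4 is thus expected to give about 4500 nM, with a plausible range from 2000 nM to 10000 nM.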

Compound 4, half-maximal inhibitory concentration: 5350 nM
Estimate against measurement, compound 4: 1.2-fold (0.08 log units) below, and the stated range covers the measured number.
By their numbers in this assay, from the lowest: compounds 3, 2, 1 and 4 (each within the scatter of the next, the first and the last beyond it).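

In this assay, putting chloro in place of trifluoromethyl on an aromatic carbon, para to a large group, gives a 1.0-fold higher number from compound 1 to compound 4 (0.01 log units; within the scatter), so compound 1 and compound 4 cannot be told apart. Among these compounds, this is the first measured step between two compounds that differ in one place only, and it shows that here the 4 heavy atoms of trifluoromethyl can give way to the 1 heavy atom of chloro with no difference that can be read on this measurement. The data offer no measured property of either group that could explain this result.

The compounds shown leave open what a group of another kind at this place, such as an amine, a carboxylic acid or a longer chain, would do to the number, as the two groups compared here are both small and uncharged. From the compounds shown here alone, it also stays open whether the same exchange would give a similar result on another compound, as compound 2 and compound 3 differ from compound 1 in more than one place and cannot answer that.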